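The source may hold more compounds than are shown below. What is called first, only, known or untested is meant among the compounds shown, and "the series" means these compounds.

Among the measured compounds shown here, in a functional assay on HEL cells (Homo sapiens) for inhibition, read by CellTiter-Glo, with a stated time of 48 h (a higher number here means a weaker inhibitor of growth, a lower number a stronger inhibitor of growth), compound 1 (`O=C(CCCCC(=O)N1C/C=C/COCc2cccc(c2)-c2ccnc(n2)Nc2cccc(c2)C1)NO`) gives 2940 nM and compound 2 (`O=C(CCCCC(=O)N1C/C=C/CCOc2cccc(c2)-c2ccnc(n2)Nc2cccc(c2)C1)NO`) gives 2110 nM, two values within the scatter of each other, so compound 1 stands level with the only other measured compound. Compound 3 (`O=C(CCCCCCC(=O)N1C/C=C/COCc2cccc(c2)-c2ccnc(n2)Nc2cccc(c2)C1)NO`) differs from compound 1 by 2-(hydroxycarbamoyl)ethyl in place of hydroxycarbamoyl on a saturated chain carbon, four bonds along the chain from a carbonyl carbon, on a saturated chain carbon, four bonds along the chain from a carbonyl carbon. For the measured compounds named here, no measured pair shows this change, so in this assay only a modest step towards a lower number is expected, possibly none beyond the scatter. The expected step is a 1.7-fold lower number from compound 1 to compound 3 (0.24 log units; within the scatter). For compound 3 the estimate is 1700 nM, with an expected range of 700 nM to 3800 nM.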

Compound 3, concentration for 50% growth inhibition: 5030 nM
Beside the measured number, compound 3's estimate is 3.0-fold (0.47 log units) below it, outside the stated range (above it).
By their numbers in this assay, from the lowest: compounds 2, 1 and 3 (each within the scatter of the next, the first and the last beyond it).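

In this assay, 2-(hydroxycarbamoyl)ethyl in place of hydroxycarbamoyl on this saturated chain carbon gives a 1.7-fold higher number from compound 1 to compound 3 (0.23 log units; within the scatter). Among the compounds shown here, this is the first reading at this position, and it places the two chain lengths level on the core of compound 1. No measurement in hand bears on the basis of this result.

Open, as far as these compounds go, is whether a longer chain, or a carboxylic acid or primary amide in place of the hydroxycarbamoyl end, would move the number beyond the scatter. Also open, from the compounds shown here alone, is whether the same chain change reads alike on the core of compound 2.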